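A few compounds are considered here, and "the series" means these few. Any claim that something is new, unique, unknown or untested is made for them only; others in the source may bear on it.

Measured compounds in an assay on CHO cells for displacement of a labelled ligand from prostaglandin E2 receptor EP1 subtype (Mus musculus), read by scintillation counting, with a stated time of 20 min; a higher number here means a weaker inhibitor, a lower number a stronger inhibitor:
compound 1 `O=C(O)CCCSCCN1C(=O)CC[C@@H]1/C=C/[C@@H](O)Cc1cccc(N2Cc3ccccc3C2)c1` gives 7100 nM
compound 2 `O=C(O)c1csc(SCCN2C(=O)CC[C@@H]2/C=C/[C@@H](O)Cc2cccc(-c3ccccc3)c2)n1` gives 4200 nM
compound 3 `Cc1ccc2oc(-c3cccc(C[C@H](O)/C=C/[C@H]4CCC(=O)N4CCSc4nc(C(=O)O)cs4)c3)nc2c1` gives 1300 nM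

Among these three, compound 3 carries the lowest inhibition constant. Among the compounds with values here, its nearest neighbour is compound 2, and the one step that runs between measured compounds, a 3.2-fold lower number from compound 2 to compound 3 (0.51 log units; beyond the scatter), lies beyond the scatter; compound 1 stands further away still, with a higher value than compound 3, and no single-point step joins it to the others.

Compound 4 `Cc1cc(C)c2oc(-c3cccc(C[C@H](O)/C=C/[C@H]4CCC(=O)N4CCSc4nc(C(=O)O)cs4)c3)nc2c1` is the next compound in this series. It differs from compound 3 in one place: methyl in place of hydrogen on an aromatic carbon. Within the data shown here, the only measured step concerns a different kind of change, the swap of a phenyl for a 5-methyl-1,3-benzoxazol-2-yl, and none of the three compounds shows the effect of an added methyl on that fused ring. There is therefore nothing in the data that points to a step of a given direction for compound 4, and the expectation is a change within the usual scatter, with the step of a 1.3-fold lower number from compound 3 to compound 4 (0.11 log units; within the scatter) estimated as small. The inhibition constant of compound 4 in this assay is estimated at 1000 nM, with a range from 400 nM to 2600 nM.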

Compound 4, inhibition constant: 3200 nM
Beside the measured number, compound 4's estimate is 3.2-fold (0.51 log units) below it; the measured number lies above the stated range.
By their numbers in this assay, from the lowest: compound 3; then compounds 4, 2 and 1 (each within the scatter of the next, the first and the last beyond it).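

In this assay the added methyl, which turns 5-methyl-1,3-benzoxazol-2-yl into 5,7-dimethyl-1,3-benzoxazol-2-yl, gives a 2.5-fold higher number from compound 3 to compound 4 (0.39 log units; beyond the scatter), so this aromatic carbon, ortho to a fused ring and meta to the existing methyl group, does respond to a single added carbon, and the response is a modest weakening. Set against the biphenyl-type compound 2, the change of phenyl to the 5,7-dimethyl-1,3-benzoxazol-2-yl group gives a 1.3-fold lower number from compound 2 to compound 4 (0.12 log units; within the scatter), which means that the advantage held by compound 3 over compound 2 is not kept once this second methyl is present. Nothing measured here speaks to the reason for this reversal.

The compounds shown leave open whether a methoxy group or a chlorine atom on this same aromatic carbon would weaken binding as the methyl does, or whether the effect is particular to methyl. They also leave open how a 1,3-benzoxazol-2-yl group with no methyl at all, or one carrying only a 7-methyl group, would compare with compound 3 and compound 4.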